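Enyne Enol Geometry and Expected Cytotoxicity

A few compounds are considered here, and "the series" means these few. Any claim that something is new, unique, unknown or untested is made for them only; others in the source may bear on it.

Measured compounds:
Compound 1 `C=CCCCCCCCC#CC#CCO` — in a functional assay on A549 cells (Homo sapiens) for cytotoxicity (a lower number here means that less compound is needed, a higher number that more compound is needed for the effect), compound 1 gives 3.9 ug/mL.
Compound 2 `C=CCCCCCC#CC#C/C(O)=C\C(C)=O` — in this assay compound 2 gives 6.39 ug/mL.
Compound 3 `C=CCCCCCC#CC#CCOCCO` — in this assay compound 3 gives 22.7 ug/mL.

Among these three numbers, compound 2 stands second highest. Its nearest neighbour is compound 1, whose number is lower, but that gap lies within the usual scatter of repeated measurements, so the two cannot be placed in any order. Compound 3 lies furthest from compound 2, with a higher number, and that gap is beyond the scatter.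

Among the measured compounds shown here, compound 4 `C=CCCCCCC#CC#C/C(O)=C/C(C)=O` has not yet been measured. the two compounds have the same atoms and bonds and differ only in configuration as drawn: 1 of 1 stereo elements differ; a double bond is drawn E in compound 2 and Z in compound 4 No step between measured compounds is available as a guide, and the change concerns only the drawn configuration, so the expectation in this assay is for no step beyond the scatter from compound 2 to compound 4, in either direction. Compound 4 is therefore estimated at 7 ug/mL, with a range from 3 ug/mL to 16 ug/mL. This estimate corresponds to an expected step of a 1.1-fold higher number from compound 2 to compound 4 (0.04 log units; within the scatter).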

Compound 4, concentration for half-maximal effect: > 30 ug/mL
Compound 4 ended at the assay's limit; the forecaster's own chance of this, stated with the estimate: 5%; middle value at least 4.2-fold (0.63 log units) away from the limit.
By their numbers in this assay, from the lowest: compounds 1 and 2 (each within the scatter of the next); then compound 3. At a limit, above all of these: compound 4.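

Among the compounds shown here, changing the enol double bond from E to Z gives an at least 4.6-fold higher number from compound 2 to compound 4 (0.67 log units; beyond the scatter) in this assay, so this position responds to configuration alone, something the earlier compounds could not show, since no two of them differed in one place. Compound 4 reads > 30 ug/mL, which is a limit of the assay and not a number. The step can be assigned to the configuration of this one double bond, the only thing that separates the pair: the fact that compounds 2 and 4 differ only in the configuration as drawn.

From the compounds shown here alone, how far compound 4 lies beyond that limit remains open, so the full size of the step is unknown. Also open, going by these compounds, is whether a carboxylic acid or an amide in place of the enol, or a longer chain, would keep this dependence on configuration.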